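This account rests on a few compounds, and the source may have more. Where it says the series, first, only, none or still open, it means among the compounds named here.

Measured so far, in a functional assay on CHO cells for antagonist activity at Orexin/Hypocretin receptor type 1 (Homo sapiens), read by FLIPR and calcium flux; a higher number here means a more potent compound, by a factor of ten per unit of this negative logarithm, a lower number a less potent compound:
Compound 1 `O=C(c1cc(Cl)ccc1-c1ncccn1)N1CC2(CC2)C[C@H]1CNc1cc(C(F)(F)F)ccn1` gives 8.1.
Compound 2 `Cc1ccc(-c2ncccn2)c(C(=O)N2CC3(CC3)C[C@H]2CNc2cc(C(F)(F)F)ccn2)n1` gives 6.

Within the data shown here, of these two numbers, compound 2 holds the lower one; compound 1 sits higher by a margin beyond the usual scatter, but no step between these two compounds is set out here, so only the two values themselves can be compared.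

Compound 3 `Cc1ccc(-c2ncccn2)c(C(=O)N2CC3(CC3)C[C@H]2CNc2ccc(C(F)(F)F)cn2)n1` is not yet measured. It is made from compound 2 by a change that keeps every atom and joins one group differently: 5-(trifluoromethyl)pyridin-2-yl in place of 4-(trifluoromethyl)pyridin-2-yl on an amine nitrogen. The shared core of compound 2 is otherwise untouched.

Among the measured compounds shown here, no measured pair shows a change of this kind, so there is nothing to scale a step by. The expected step from compound 2 to compound 3 in this assay is no change at the digits printed from compound 2 to compound 3 (within the scatter), and it is expected to stay within the scatter, with no clear direction. Compound 3 is therefore estimated at 6, with a range from 5.3 to 6.8. Because compound 2 gives 6 a low reading is expected for compound 3.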

Compound 3, negative logarithm of the antagonist equilibrium constant: 8.4
Compound 3: middle estimate off by 2.40 log units, on the low side, outside the stated range (above it).
By their numbers in this assay, from the lowest: compound 2; then compounds 1 and 3 (each within the scatter of the next).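

In this assay, placing 5-(trifluoromethyl)pyridin-2-yl in place of 4-(trifluoromethyl)pyridin-2-yl on the amine nitrogen gives a number 2.40 log units higher from compound 2 to compound 3 (beyond the scatter) in a single step, a large change for a swap that adds and removes no atoms. The two groups have the same atoms, the same ring and the same counts of hydrogen-bond donors and acceptors, so the difference between compound 2 and compound 3 lies only in how the group is joined, and this part of the molecule proves highly sensitive to that arrangement. Compounds 1 and 2 could not show this, as both carry the 4-(trifluoromethyl)pyridin-2-yl group and differ elsewhere, while the data here offer no measurement that explains the size of the step.

As far as these compounds go, it remains open whether the same swap would give a step of similar size on the core of compound 1, which carries a different acyl part. From the compounds shown here alone, it is also open how a nitrile or a methoxy group in place of the trifluoromethyl would behave on this pyridine ring.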